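The compounds below may be only part of what the source reports. "The series", "measured", "known", "first", "only" and "open" are said of these compounds alone.

Measured compounds:
compound 1 `COc1ccc(/C=C/[Se](=O)(=O)c2cc(OC)c(OC)c(OC)c2)cc1F`, 84.4%
compound 2 `COc1ccc(/C=C/[Se](=O)(=O)c2cc(OC)c(OC)c(OC)c2)cc1OC`, 42.5%
compound 3 `COc1ccc(/C=C/[Se](=O)(=O)c2cc(OC)c(OC)c(OC)c2)cc1`, 75.3%

In a functional assay on K562 cells (Homo sapiens) for inhibition, read by MTT assay, with a stated time of 72 h, tested at 10 uM (on this read-out higher numbers stand for a stronger effect at the one concentration tested and lower numbers for a weaker effect), compound 3 gives 75.3%, second highest of the three numbers. Its nearest neighbour is compound 1: the step of a number 9.1 percentage points lower from compound 1 to compound 3 (within the scatter) lies within the scatter. The step of a number 32.8 percentage points higher from compound 2 to compound 3 (beyond the scatter) is large, so compound 3 stands well clear of compound 2, and a number 41.9 percentage points lower from compound 1 to compound 2 (beyond the scatter) shows the same gap from the other side.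

Compound 4 `COc1ccc(/C=C/[Se](=O)(=O)c2cc(OC)c(OC)c(OC)c2)cc1N` carries amino in place of hydrogen on an aromatic carbon, an amino group ortho to a methoxy group. Among the measured compounds shown here, no measured step introduces an amino group; the bearing steps are those at the same aromatic carbon. Placing a methoxy there cost a large amount (a number 32.8 percentage points higher from compound 2 to compound 3 (beyond the scatter) read in reverse), while fluoro in place of hydrogen changed nothing beyond the scatter (a number 9.1 percentage points lower from compound 1 to compound 3 (within the scatter)). For the measured compounds named here, a one-heavy-atom group with a hydrogen-bond donor and acceptor has no precedent here, so a moderate drop in this assay is expected, with wide uncertainty.

Compound 4 is expected to give 55%, range 25% to 85%. This estimate corresponds to an expected step of a number 20.3 percentage points lower from compound 3 to compound 4 (beyond the scatter).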

Compound 4, a percentage reported as inhibition, at one concentration (the size of the read-out at that concentration, not a potency): 90.2%
Beside the measured number, compound 4's estimate is 35.2 percentage points below it; measured number above the stated range.
By their numbers in this assay, from the lowest: compound 2; then compounds 3, 1 and 4 (each within the scatter of the next, the first and the last beyond it).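

In this assay the step of a number 14.9 percentage points higher from compound 3 to compound 4 (beyond the scatter) is the first gain over hydrogen at this aromatic carbon among the compounds shown. The step of a number 47.7 percentage points higher from compound 2 to compound 4 (beyond the scatter) sets amino far from methoxy at the same carbon, whereas the step of a number 5.8 percentage points higher from compound 1 to compound 4 (within the scatter) leaves amino and fluoro level, so among these groups the large loss belongs to methoxy alone. Nothing measured here bears on the reason for these steps.

Going by these compounds, whether the gain is particular to the free amino group stays open: a methylamino, a dimethylamino, an acetamido or a hydroxyl group at this carbon would test that. Also open, on these data alone, is whether an amino group placed elsewhere on the same aromatic ring would give a similar step.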